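Removing a ring hydroxy from compound 1

This account rests on a few compounds, and the source may have more. Where it says the series, first, only, none or still open, it means among the compounds named here.

Compound 1 `CC(=O)N(Cc1ncnc2c1ncn2[C@@H]1O[C@H](CO)[C@@H](O)[C@H]1O)C1CCCCC1` is the cyclohexyl amide of the series. In a functional assay on Huh-7 cells (Homo sapiens) for cytotoxicity, read by MTT assay, with a stated time of 3 days (a higher number here means that more compound is tolerated, a lower number that less compound is tolerated), compound 1 gives > 100000 nM, which is a limit of the assay and not a number. Compound 3 `CC(=O)N(Cc1ccccc1)Cc1ncnc2c1ncn2[C@@H]1O[C@H](CO)[C@@H](O)[C@H]1O` carries benzyl in place of cyclohexyl on an amide-type nitrogen; in this assay compound 3 gives > 100000 nM, likewise a limit. The step that the two limits leave unreadable from compound 1 to compound 3 is therefore not readable in size. Compound 2 `OC[C@H]1O[C@@H](n2cnc3c(COc4ccccn4)ncnc32)[C@H](O)[C@@H]1O` in this assay gives > 250000 nM, again a limit. For the measured compounds named here, compound 1 thus stands at the limit of > 100000 nM in this assay, at which 2 of the 3 values shown sit; no compound in the set has a measured number, and the remaining figure sits at the limit of > 250000 nM in this assay, at which 1 of the 3 values shown sits.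

Compound 4 `CC(=O)N(Cc1ncnc2c1ncn2[C@H]1C[C@H](O)[C@@H](CO)O1)C1CCCCC1` differs from compound 1 by hydrogen in place of hydroxy on a saturated ring carbon. The only step shown, a step that the two limits leave unreadable from compound 1 to compound 3, concerns the amide-type nitrogen, not the five-membered non-aromatic ring with 1 oxygen, and its size is hidden by the two limits. No measured step therefore bears on the change, and no direction or size beyond the scatter can be expected in this assay from the data shown. The expectation is that compound 4 remains at or close to the limit where compound 1 sits, at > 100000 nM. For compound 4 in this assay the estimate is 100000 nM, within 30000 nM to 300000 nM; the expected step is a number no higher from compound 1 to compound 4 (the limit leaves the size open).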

Compound 4, half-maximal cytotoxic concentration: > 100000 nM
Compound 4 ended at the assay's limit; the forecaster's own chance of this, stated with the estimate: 80%; the middle value sits exactly at the limit.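

Compound 1 and compound 4 both stand at a limit and not at a number in this assay, so the step between them cannot be read. The compounds shown leave open at what concentration any of them turns cytotoxic, and so whether replacing the ring hydroxy with hydrogen changes tolerance at all; most values share one limit: the limit of > 100000 nM in this assay, at which 3 of the 4 values shown sit.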